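This account rests on a few compounds, and the source may have more. Where it says the series, first, only, none or still open, it means among the compounds named here.

Of the compounds shown here, three built on one shared core have been measured in a functional assay on NCI-H1975 cells (Homo sapiens) for inhibition, read by sulforhodamine B assay, tested at 10 uM (on this read-out lower numbers stand for less inhibition and higher numbers for more inhibition at the one concentration tested (going by the name of the read-out)), and they differ only in the group that sits on an aromatic carbon of a six-membered aromatic ring of carbon only, para to a large group. Compound 1 `Cc1ccc(S(=O)(=O)N2N=C(c3ccc(N4CCN(C)CC4)cc3)CC2c2ccc(N(C)C)cc2)cc1` carries a methyl there and gives 38.1%. Compound 2 `CN1CCN(c2ccc(C3=NN(S(=O)(=O)c4ccc(Br)cc4)C(c4ccc(N(C)C)cc4)C3)cc2)CC1` carries a bromo at that place and gives 70.8%. Compound 3 `CN1CCN(c2ccc(C3=NN(S(=O)(=O)c4ccc(C#N)cc4)C(c4ccc(N(C)C)cc4)C3)cc2)CC1` carries a cyano there and gives 100%, the highest of the three numbers, with compound 2 nearest to it and compound 1 furthest away. Every step among them lies beyond the scatter: a number 32.7 percentage points higher from compound 1 to compound 2 (beyond the scatter), a number 61.9 percentage points higher from compound 1 to compound 3 (beyond the scatter) and a number 29.2 percentage points higher from compound 2 to compound 3 (beyond the scatter).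

Compound 4 `CN1CCN(c2ccc(C3=NN(S(=O)(=O)c4ccc(OC(F)(F)F)cc4)C(c4ccc(N(C)C)cc4)C3)cc2)CC1` has not yet been measured. It differs from compound 3 in a single place: trifluoromethoxy in place of cyano on an aromatic carbon. Among the compounds with values here, no measured pair exchanges cyano for trifluoromethoxy, so the three known steps bear on compound 4 only by showing that changing the group at this place has shifted the number each time, by modest to large amounts. Compound 3 already stands at the top of the scale, so any step beyond the scatter can only run downward. Compound 4 is therefore expected to give 75%, estimated to fall between 45% and 100%. The step expected from this estimate is a number 25 percentage points lower from compound 3 to compound 4 (beyond the scatter).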

Compound 4, a percentage reported as inhibition, at one concentration (the size of the read-out at that concentration, not a potency): 26.5%
Compound 4: the middle estimate sits 48.5 percentage points above what was measured; the measured number lies below the stated range.
By their numbers in this assay, from the lowest: compound 4; then compound 1; then compound 2; then compound 3.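

Compound 4 shows that this position can do more than raise the number: in this assay, trifluoromethoxy gives the lowest reading of the four groups, with a number 73.5 percentage points lower from compound 3 to compound 4 (beyond the scatter) and a number 44.3 percentage points lower from compound 2 to compound 4 (beyond the scatter) and a number 11.6 percentage points lower from compound 1 to compound 4 (beyond the scatter). The earlier compounds shown here showed only a climb from methyl through bromo to cyano, so they left it possible that methyl marked the low end, whereas this result sets a new floor for the series and makes the exchange of cyano for trifluoromethoxy the largest step seen so far, with 5 heavy atoms entering where 2 leave. No measurement at hand explains why these groups fall in this order.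

The compounds shown leave open whether the low reading goes with the oxygen link or with the fluorines, a question that methoxy and trifluoromethyl at the same place would help to separate. They also leave open how a group of a different kind, such as an amine or a carboxylic acid, would read at this position.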